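The source may report more compounds than this note shows. Statements on the series, on what has been measured and on what is new or still open speak of the compounds shown alone.

Compound 1 `CC(C)OC(=O)OCOC(=O)C1=C(S[C@@H]2CN[C@H](C(=O)Nc3cccc(C(=O)O)c3)C2)[C@H](C)[C@@H]2[C@@H]([C@@H](C)O)C(=O)N12` is the reference point of this account. In an ADME assay for metabolic stability, read by LC-MS, with a stated time of 3 h, at pH 6.5, tested at 50 uM (on this read-out lower numbers stand for a less stable compound and higher numbers for a more stable compound), compound 1 gives > 95%, a value that is a limit of the assay rather than a number. Compound 2 `CCC(CC)C(=O)OCOC(=O)C1=C(S[C@@H]2CN[C@H](C(=O)Nc3cccc(C(=O)O)c3)C2)[C@H](C)[C@@H]2[C@@H]([C@@H](C)O)C(=O)N12` differs from it by a pentan-3-yl in place of isopropoxy on a carbonyl carbon. In this assay compound 2 gives > 95%, which is again a limit of the assay. Going by the values given here, the step that the two limits leave unreadable from compound 1 to compound 2 therefore cannot be read, and the only evidence on the measured pair is the limit of > 95% in this assay, at which 2 of the 2 values shown sit. Compound 3 `CC(C)OC(=O)OCOC(=O)C1=C(S[C@@H]2CN[C@H](C(=O)Nc3cccc(C(=O)OCOC(=O)OC(C)C)c3)C2)[C@H](C)[C@@H]2[C@@H]([C@@H](C)O)C(=O)N12` has not yet been measured; it carries ((isopropoxycarbonyl)oxy)methyl in place of hydrogen on an oxygen next to a carbonyl group. Among the compounds with values here, no measured step bears directly on this change, so the single comparison available shows only that both measured compounds sit at the same limit. Compound 3 is therefore expected to remain close to that limit in this assay, with the step of a number at least 3 percentage points lower from compound 1 to compound 3 (that floor lies within the scatter) expected to be small. The estimate for compound 3 is 92%, with a range from 70% to 99%, and a fair chance that the assay again reports only a limit.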

Compound 3, percent of the compound remaining: > 95%
Compound 3 ended at the assay's limit; the forecaster's own chance of this, stated with the estimate: 60%; middle value at least 3 percentage points from the limit.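

In this assay compound 3 gives > 95%, which is a limit of the assay and not a number. Compound 1 also stands at a limit, so no step from it to compound 3 can be read: the limit of > 95% in this assay, at which 3 of the 3 values shown sit.

The compounds shown leave open whether either change alters the percent of compound remaining; none gives a readable number.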